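The compounds below may be only part of what the source reports. "The series", "measured", "known", "first", "only" and "open" are said of these compounds alone.

Measured in an ADME assay on WI-38 cells (Homo sapiens) for cytotoxicity, read by MTT assay, with a stated time of 72 h (a lower number here means a stronger inhibitor, a higher number a weaker inhibitor), so far:
Compound 1 `CC(C)(C)NC(=O)CCc1cccc2c1B(O)OC2` gives > 100000 nM (a limit of the assay)
Compound 2 `O=C(CCc1cccc2c1B(O)OC2)Nc1nccs1` gives > 100000 nM (a limit of the assay)
Compound 3 `O=C(CCc1cccc2c1B(O)OC2)Nc1ccc(F)cc1` gives 12000 nM

Within the data shown here, compound 3 holds the only actual number of the three, and it is the most cytotoxic of them in this assay. Compound 4 `O=C(CCc1cccc2c1B(O)OC2)Nc1ccc(I)cc1` differs from it by iodo in place of fluoro on an aromatic carbon, with iodo in place of fluoro on an aromatic carbon, para to a large group.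

Among the measured compounds shown here, no measured step exchanges one halogen for another, so the evidence is indirect. Placing 4-fluorophenyl on the amide-type nitrogen in place of tert-butyl gave an at least 8.3-fold lower number from compound 1 to compound 3 (0.92 log units; beyond the scatter). Placing it there in place of 1,3-thiazol-2-yl gave an at least 8.3-fold lower number from compound 2 to compound 3 (0.92 log units; beyond the scatter). On these data alone, both steps start from the limit of > 100000 nM in this assay, at which 2 of the 3 values shown sit, so their full size stays open.

These steps concern the whole group on the nitrogen, whereas compound 4 keeps the phenyl ring and changes only its halogen. No step beyond the scatter is therefore expected in this assay, with only a slight lean towards a lower number. The expected change is a 1.3-fold lower number from compound 3 to compound 4 (0.12 log units; within the scatter). For compound 4 the estimated value is 9000 nM, with an expected range from 3500 nM to 30000 nM.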

Compound 4, half-maximal inhibitory concentration: 49000 nM
The estimate for compound 4 lay 5.4-fold (0.74 log units) below the measured number; measured number outside the range, above it.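

In this assay, the halogen on the phenyl ring proves to be more than a minor detail: iodo in place of fluoro, para to a large group, gives a 4.1-fold higher number from compound 3 to compound 4 (0.61 log units; beyond the scatter), so a change of this single atom at this position registers in the read-out. Against the other two groups on the amide-type nitrogen, the comparisons read an at least 2.0-fold lower number from compound 2 to compound 4 (0.30 log units; that floor lies within the scatter) and an at least 2.0-fold lower number from compound 1 to compound 4 (0.30 log units; that floor lies within the scatter), and on these floors alone the phenyl ring with iodo is not clearly set apart from either group. The full size of both comparisons stays open, because both start from the same point: the limit of > 100000 nM in this assay, at which 2 of the 4 values shown sit.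

The compounds shown carry only fluoro and iodo at this place, so it remains open where chloro, bromo, methoxy or an amine there would stand in this assay. On these data alone, it is equally open whether the exchange of fluoro for iodo would give a step of similar size in a compound with a longer chain leading to the amide.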